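The source may report more compounds than this note shows. Statements on the series, on what has been measured and on what is new or still open speak of the compounds shown alone.

In an ADME assay on Vero cells (Chlorocebus sabaeus) for cytotoxicity, read by MTT assay, with a stated time of 48 h (a higher number here means a weaker inhibitor, a lower number a stronger inhibitor), compound 1 `O=c1nc(NCc2ccc(F)cc2)oc2c([N+](=O)[O-])cc(C(F)(F)F)cc12` gives > 64 ug/mL, a limit of the assay. Compound 2 `O=c1nc(NCc2cccc(F)c2)oc2c([N+](=O)[O-])cc(C(F)(F)F)cc12` gives > 64 ug/mL, also a limit. For the measured compounds named here, compound 3 `O=c1nc(NCC2CCCCC2)oc2c([N+](=O)[O-])cc(C(F)(F)F)cc12` gives 29.7 ug/mL, the only number among the three, with the other two values sitting at the limit of > 64 ug/mL in this assay, at which 2 of the 3 values shown sit. The measured steps of an at least 2.1-fold lower number from compound 1 to compound 3 (0.33 log units; beyond the scatter) and an at least 2.1-fold lower number from compound 2 to compound 3 (0.33 log units; beyond the scatter) both concern the exchange of a fluorophenyl for the cyclohexyl ring and say nothing about shortening the chain. Compound 4 `O=c1nc(NC2CCCCC2)oc2c([N+](=O)[O-])cc(C(F)(F)F)cc12` differs from compound 3 by cyclohexyl in place of cyclohexylmethyl on a nitrogen on an aromatic ring. Going by the values given here, no measured step bears on this change, so no step beyond the scatter is expected in this assay, an expected 1.1-fold higher number from compound 3 to compound 4 (0.03 log units; within the scatter). Compound 4 is therefore estimated at 32 ug/mL, between 14 ug/mL and 70 ug/mL.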

Compound 4, half-maximal inhibitory concentration: 5.39 ug/mL
Compound 4: middle estimate off by 5.9-fold (0.77 log units), on the high side; measured number below the stated range.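

With the six-membered ring kept and only cyclohexylmethyl exchanged for cyclohexyl, this assay shows a 5.5-fold lower number from compound 3 to compound 4 (0.74 log units; beyond the scatter), so this position responds to more than the exchange of a fluorophenyl ring for a cyclohexyl ring. Set against the fluorobenzyl compounds, the result is an at least 11-fold lower number from compound 2 to compound 4 (1.07 log units; beyond the scatter) and an at least 11-fold lower number from compound 1 to compound 4 (1.07 log units; beyond the scatter). Both of these steps are bounds only, because each starts from a limit: the limit of > 64 ug/mL in this assay, at which 2 of the 4 values shown sit.

On these data alone, whether a cyclohexylethyl chain would continue this trend remains open. So does whether a cyclopentyl ring on the nitrogen would give a number like that of compound 4.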